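This account rests on a few compounds, and the source may have more. Where it says the series, first, only, none or still open, it means among the compounds named here.

Measured so far in an assay on cells with melanin-concentrating hormone receptor 1 (Homo sapiens) as the target, read by radioligand binding; a lower number here means a stronger inhibitor, a higher number a weaker inhibitor:

- compound 1 `CC(C)Oc1cccc2ccc(N)nc12` gives 437 nM
- compound 2 `Nc1ccc2cccc(OCC3CCOC3)c2n1` gives 115 nM
- compound 3 `Nc1ccc2cccc(OCC3CCC3)c2n1` gives 432 nM

Compound 1 stands at the highest of the three numbers, though its value and that of compound 3 are within the scatter of each other; compound 2 is furthest from it, with a 3.8-fold lower number from compound 1 to compound 2 (0.58 log units; beyond the scatter).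

Compound 4 `Nc1ccc2cccc(OCCC3CC3)c2n1` has not yet been tested. Relative to compound 1 the change is 2-cyclopropylethyl in place of isopropyl on an oxygen on an aromatic ring.

Within the data shown here, two measured steps bear on this. a 1.0-fold lower number from compound 1 to compound 3 (0.00 log units; within the scatter) shows that replacing isopropyl with a carbon-only ring-bearing chain leaves the number unchanged. a 3.8-fold lower number from compound 1 to compound 2 (0.58 log units; beyond the scatter) is modest, but the entering oxolan-3-yl group brings an acceptor, which 2-cyclopropylethyl does not; a 3.8-fold higher number from compound 2 to compound 3 (0.57 log units; beyond the scatter) shows the same gap from the other side. Compound 4 is therefore expected to behave like compound 3, with no step beyond the scatter, a 1.0-fold lower number from compound 1 to compound 4 (0.02 log units; within the scatter). The estimate for compound 4 in this assay is 420 nM, with a range from 200 nM to 900 nM.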

Compound 4, half-maximal inhibitory concentration: 492 nM
For compound 4 the middle estimate is 1.2-fold (0.07 log units) below the measured one; low and high end bracket the measured number.
By their numbers in this assay, from the lowest: compound 2; then compounds 3, 1 and 4 (each within the scatter of the next).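

In this assay, on an oxygen on an aromatic ring, 2-cyclopropylethyl with 5 heavy atoms reads the same as isopropyl with 3 (a 1.1-fold higher number from compound 1 to compound 4 (0.05 log units; within the scatter)), and it also matches the cyclobutylmethyl group (a 1.1-fold higher number from compound 3 to compound 4 (0.06 log units; within the scatter)). The three carbon-only groups thus stay within the scatter of one another, so this position accepts a three-membered ring on a two-carbon link without a readable change. The oxolan-3-yl group of compound 2 remains the only one set apart from the others, and the new step widens the evidence for that separation (a 4.3-fold higher number from compound 2 to compound 4 (0.63 log units; beyond the scatter)).

As far as these compounds go, whether the ring oxygen of compound 2 is required remains open, and a methoxyethyl chain or a tertiary amine at this position would test other atoms there. No measurement here explains these differences or this lack of difference.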